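The compounds below may be only part of what the source reports. "The series", "measured", "known", "first", "only" and "open" are said of these compounds alone.

Compound 1 `COc1cc(-c2cc(/C=C/C(=O)c3ccc(N)cc3)[nH]n2)cc(OC)c1OC`: 51600 nM
Compound 2 `COc1ccc(C(=O)/C=C/c2cc(-c3cc(OC)c(OC)c(OC)c3)n[nH]2)cc1OC`: 5100 nM

In a functional assay on TK-10 cells (Homo sapiens) for inhibition, read by sulforhodamine B assay, with a stated time of 48 h (on this read-out higher numbers stand for lower toxicity in this test and lower numbers for higher toxicity in this test), compound 2 has the lower number of the pair, at 5100 nM. Compound 3 `COc1cc(-c2cc(/C=C/C(=O)c3ccc(F)c(F)c3)[nH]n2)cc(OC)c1OC` has 3,4-difluorophenyl in place of 3,4-dimethoxyphenyl on a carbonyl carbon. One measured step changes the group at this same place: a 10-fold lower number from compound 1 to compound 2 (1.01 log units; beyond the scatter). That large step shows how far the number can move here, but it involves a different group, so it is only a loose guide. A modest move towards a higher number is expected. The estimate for compound 3 is 11000 nM, with a range of 2500 nM to 40000 nM. This would be an expected 2.2-fold higher number from compound 2 to compound 3 (0.33 log units; beyond the scatter).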

Compound 3, concentration lethal to 50% of the cells: > 100000 nM
Compound 3: only a limit was reported; the forecaster's own chance of this, stated with the estimate: 15%; middle value at least 9.0-fold (0.95 log units) away from the limit.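

In this assay, the result for compound 3 is a limit rather than a number: the limit of > 100000 nM in this assay, at which 1 of the 3 values shown sits. With 3,4-difluorophenyl in place of 3,4-dimethoxyphenyl on the carbonyl carbon, the data show an at least 19-fold higher number from compound 2 to compound 3 (1.29 log units; beyond the scatter), so this position can move the number strongly upward as well as downward, and the 3,4-dimethoxyphenyl group gives the lowest number of the three. Against 4-aminophenyl, the change gives an at least 1.9-fold higher number from compound 1 to compound 3 (0.28 log units; that floor lies within the scatter), a floor too small to set the two apart.

On these data alone, it remains open whether a group with a single methoxy, such as 4-methoxyphenyl, would keep the low number. The same is true of a group with two hydroxyls, such as 3,4-dihydroxyphenyl.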